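Note on the series: phenyl added to the core

A few compounds are considered here, and "the series" means these few. Any claim that something is new, unique, unknown or untested is made for them only; others in the source may bear on it.

The shared core carries a saturated chain carbon on an aromatic nitrogen, and the three measured compounds differ only there. Compound 1 `Cn1c2ccccc2[n+]2nc3c(cc12)-c1cccc2cccc-3c12` gives 3700 nM in a functional assay on HT-29 cells (Homo sapiens) for inhibition, with a stated time of 72 h; a lower number here means that less compound is needed, a higher number that more compound is needed for the effect. Compound 2 `CCOC(=O)Cn1c2ccccc2[n+]2nc3c(cc12)-c1cccc2cccc-3c12` gives 54000 nM in this assay, and compound 3 `c1ccc(Cn2c3ccccc3[n+]3nc4c(cc23)-c2cccc3cccc-4c23)cc1` gives 1500 nM. Compound 3 stands lowest of the three: a 2.5-fold lower number from compound 1 to compound 3 (0.39 log units; beyond the scatter), a 36-fold lower number from compound 2 to compound 3 (1.56 log units; beyond the scatter), while a 15-fold higher number from compound 1 to compound 2 (1.16 log units; beyond the scatter).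

Compound 4 `c1ccc(Cn2c3ccccc3[n+]3nc4c(c(-c5ccccc5)c23)-c2cccc3cccc-4c23)cc1` is not yet measured. It differs from compound 3 in one place: phenyl in place of hydrogen on an aromatic carbon. Going by the values given here, no measured step touches this part of the core; all three measured steps change only the substituent on the chain carbon, so none bears directly on the change from compound 3 to compound 4. With no guidance from the measured steps, the expected step of a 1.3-fold higher number from compound 3 to compound 4 (0.12 log units; within the scatter) is none beyond the scatter, with a wide allowance either way. For compound 4 in this assay the estimate is 2000 nM, expected to fall between 500 nM and 8000 nM.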

Compound 4, half-maximal effective concentration: 3700 nM
For compound 4 the middle estimate is 1.9-fold (0.27 log units) below the measured one, within the range that was stated.
By their numbers in this assay, from the lowest: compound 3; then compounds 1 and 4 (each within the scatter of the next); then compound 2.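

Going by these compounds alone, this aromatic carbon, two atoms from the ring nitrogen, is a part of the core that the earlier compounds left unchanged, and in this assay phenyl in place of hydrogen there gives a 2.5-fold higher number from compound 3 to compound 4 (0.39 log units; beyond the scatter). The position therefore responds to substitution, although this modest step is much smaller than the large one on the chain carbon, a 15-fold higher number from compound 1 to compound 2 (1.16 log units; beyond the scatter). It also runs in the opposite direction to the modest step with phenyl on the chain carbon, a 2.5-fold lower number from compound 1 to compound 3 (0.39 log units; beyond the scatter). Nothing available explains the higher number for compound 4.

On these data alone, whether an amine, a methyl group or a carboxylic acid on this aromatic carbon would give a step of similar size remains open. Also open, as far as these compounds go, is whether phenyl here would give the same step with a methyl group or an ethoxycarbonyl group's chain on the aromatic nitrogen, as in compound 1 or compound 2.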